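Trading a ring for a chain on compound 2

The compounds below may be only part of what the source reports. "The series", "measured", "known", "first", "only" and "open" are said of these compounds alone.

In an ADME assay on a cell-free system (plasma, Rattus norvegicus) (a higher number here means a larger unbound share of the compound, a lower number a smaller unbound share), compound 2 (`CC(=O)Nc1cc(-c2ccc(N(C)C(=O)c3c(F)cccc3Cl)c(N3CCCCC3)c2)n(C(C)C)n1`) gives 0.001 and sits at the low end of this small set. Compound 3 (`CC(=O)Nc1cc(-c2ccc(N(C)C(=O)c3c(F)cccc3Cl)c(N3CC4CC4C3)c2)n(C(C)C)n1`) gives 0.002; 0.002 (2 entries) in both of its entries, which lies within the usual scatter of compound 2. Compound 1 (`CC(=O)Nc1cc(-c2cnc(N(C)C(=O)c3c(F)cccc3Cl)c(N3CC4CC4C3)c2)n(C(C)C)n1`) gives 0.022 and stands clearly apart from compound 2, beyond the scatter.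

The next molecule, compound 4 (`CC(=O)Nc1cc(-c2ccc(N(C)C(=O)c3c(F)cccc3Cl)c(OCC(C)C)c2)n(C(C)C)n1`), has not been measured yet. It carries isobutoxy in place of piperidin-1-yl on an aromatic carbon. Among the measured compounds shown here, no measured pair shows this exchange, so the expectation is only a rough one. Compound 4 keeps the core of compound 2, and with compound 3 at 0.002; 0.002 (2 entries) also low, a large jump seems unlikely. The expected step of a 2.0-fold higher number from compound 2 to compound 4 (0.30 log units; within the scatter) is a small rise, about the size of the usual scatter. Compound 4 is estimated at 0.002 within a range of 0.001 to 0.005 when it is measured.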

Compound 4, unbound fraction: 0.002
Estimate against measurement, compound 4: no gap at the digits printed; the measured number falls inside the stated range.
By their numbers in this assay, from the lowest: compounds 2 and 4 (each within the scatter of the next); then compound 1.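

In this assay, placing isobutoxy instead of piperidin-1-yl on this aromatic carbon gives a 2.0-fold higher number from compound 2 to compound 4 (0.30 log units; within the scatter) and so leaves the result within the normal spread of repeat measurements. Among the compounds shown here, this is the first comparison in the set at this position, and it shows that an open chain carrying oxygen can replace a six-membered non-aromatic ring carrying nitrogen without a clear shift in the unbound fraction. No measurement shown here offers a reason for this result.

Still open, going by these compounds, is whether a shorter ether such as methoxy, or a carboxylic acid, at this position would move the unbound fraction beyond that spread. Also open, on these data alone, is whether isobutoxy would behave in the same way on the core of compound 1, which gives 0.022 in this assay.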